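Compound 3: will the limit hold?

This account rests on a few compounds, and the source may have more. Where it says the series, first, only, none or still open, it means among the compounds named here.

Compound 1 `COc1ccc(-c2nc(COc3cccc(Cl)c3)nc3ccsc23)cn1` gives > 50000 nM as a limit
Compound 2 `COc1ccc(-c2nc(CSc3ccc(F)cc3F)nc3ccsc23)cn1` gives > 50000 nM as a limit

In an ADME assay on cells (Homo sapiens) for cytotoxicity, read by resazurin assay, with a stated time of 5 days (on this read-out higher numbers stand for lower toxicity in this test and lower numbers for higher toxicity in this test), compound 2 stands at > 50000 nM as a limit of the assay and not as a number. The data show the limit of > 50000 nM in this assay, at which 2 of the 2 values shown sit, and no exact reading. Compound 3 `COc1ccc(-c2nc(CSc3cc(Cl)ccc3Cl)nc3ccsc23)cn1` keeps the shared core and changes one group, with 2,5-dichlorophenyl in place of 2,4-difluorophenyl on a sulfur, counted as 2,5-dichlorophenyl in place of 2,4-difluorophenyl on a sulfur in full. For the measured compounds named here, the only measured step that bears on this is a step that the two limits leave unreadable from compound 1 to compound 2 and so no size can be carried over. Resting on compound 2 at > 50000 nM as a limit, no step beyond the usual scatter is expected. The expected step is a number no higher from compound 2 to compound 3 (the limit leaves the size open) in this assay as an estimate only. For compound 3 the estimated value is 50000 nM with an expected range from 25000 nM to 100000 nM and the assay may well report only a limit again.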

Compound 3, half-maximal cytotoxic concentration: > 50000 nM
Compound 3 gave a limit, no number (the forecaster's own chance of this, stated with the estimate: 75%); the middle value lies on the limit itself.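

No size can be read for any step among compound 1, compound 2 and compound 3 in this assay, since each gives only a limit: the limit of > 50000 nM in this assay, at which 3 of the 3 values shown sit. The compounds shown leave open where their true values lie and whether those values differ at all.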